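A few compounds are considered here, and "the series" means these few. Any claim that something is new, unique, unknown or untested is made for them only; others in the source may bear on it.

Compound 1 `Cc1cccc2c1nc(C)n2-c1ccc(C(=O)NC2CC2)s1` (10 mL/min/kg)
Compound 2 `Cc1nc2ccc(OC(F)(F)F)cc2n1-c1ccc(C(=O)NC2CC2)s1` (10 mL/min/kg)
Compound 3 `Cc1nc2cc(C(F)(F)F)ccc2n1-c1ccc(C(=O)NC2CC2)s1` (4 mL/min/kg)

In an in vitro ADME assay on microsomes from liver (Homo sapiens) for pharmacokinetics, read by LC-MS (on this read-out higher numbers stand for fast clearance and lower numbers for slow clearance), compound 2 (10 mL/min/kg) stands level with compound 1 (10 mL/min/kg), and together they give the highest of the three numbers. Compound 3 (4 mL/min/kg) lies lower, beyond the scatter. Compound 4 `Cc1nc2ccc(F)cc2n1-c1ccc(C(=O)NC2CC2)s1` carries fluoro in place of trifluoromethoxy on an aromatic carbon and has not yet been measured. Going by the values given here, no measured pair shows this change directly, so the only guide is the narrow spread of the series, from compound 3 (4 mL/min/kg) to compound 2 (10 mL/min/kg). The expected step (a 1.4-fold lower number from compound 2 to compound 4 (0.15 log units; within the scatter)) is small and downward, and it is not expected to exceed the scatter. In this assay compound 4 is estimated at 7 mL/min/kg in an expected range from 3.5 mL/min/kg to 14 mL/min/kg as the likely outcome.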

Compound 4, clearance: < 4 mL/min/kg
Compound 4: a limit, no number; the forecaster's own chance of this, stated with the estimate: 5%; at least 1.7-fold (0.24 log units) between middle value and limit.
By their numbers in this assay, from the lowest: compound 3; then compounds 1 and 2 (each within the scatter of the next).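

In this assay, fluoro in place of trifluoromethoxy on an aromatic carbon gives an at least 2.5-fold lower number from compound 2 to compound 4 (0.39 log units; beyond the scatter). Compound 4 gives < 4 mL/min/kg, which is a limit of the assay and not a number. Going by these compounds alone, this is the first pair to differ in one place, and it shows that the read-out at this position depends on the group carried there.

From the compounds shown here alone, whether a chlorine, a methoxy group or an amine at this position would read like fluoro or like trifluoromethoxy stays open. How far the step reaches is also open: the limit of < 4 mL/min/kg in this assay, at which 1 of the 4 values shown sits.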